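The source may report more compounds than this note shows. Statements on the series, on what has been measured and on what is new or still open speak of the compounds shown alone.

Measured compounds in this set:

- compound 1 `c1cc([C@H]2CC[C@]3(CC2)OOC2(O3)C3CC4CC(C3)CC2C4)ccc1OCC1CCNCC1`: 12.5 ug/mL
- compound 3 `NC1CCN(S(=O)(=O)c2ccc([C@H]3CC[C@]4(CC3)OOC3(O4)C4CC5CC(C4)CC3C5)cc2)CC1`: 12.5 ug/mL
- compound 2 `CS(=O)(=O)N1CCN(CCCOc2ccc([C@H]3CC[C@]4(CC3)OOC3(O4)C4CC5CC(C4)CC3C5)cc2)CC1`: reported only as a limit, < 1.6 ug/mL

In a physicochemical assay for solubility, read by nephelometry, measured as kinetic solubility, with a stated time of 30 min (a higher number here means a more soluble compound, a lower number a less soluble compound), compound 1 gives 12.5 ug/mL. Compound 3 gives 12.5 ug/mL in this assay. Compound 2 reaches only < 1.6 ug/mL, which is a limit of this assay and not a number; it sits at the limit of < 1.6 ug/mL in this assay, at which 1 of the 3 values shown sits, so where compound 2 actually stands on the scale is known only as a range. Two measured steps connect these compounds: an at least 7.8-fold lower number from compound 1 to compound 2 (0.89 log units; beyond the scatter), and no change at the digits printed from compound 1 to compound 3 (within the scatter).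

Compound 4 `c1cc([C@H]2CC[C@]3(CC2)OOC2(O3)C3CC4CC(C3)CC2C4)ccc1OCCOC1CCNCC1` has not been measured in this assay. Its relation to compound 2 is (piperidin-4-yl)oxy in place of (4-(methylsulfonyl)piperazin-1-yl)methyl on a saturated chain carbon, two bonds along the chain from an oxygen on an aromatic ring. For the measured compounds named here, the entering piperidin-4-yl group with its one hydrogen-bond donor is the same type of ring that compound 1 carries, and the only step that touches this part of the molecule, an at least 7.8-fold lower number from compound 1 to compound 2 (0.89 log units; beyond the scatter), ran in the direction of the methylsulfonylpiperazine and was beyond the scatter. Reversing that kind of change is therefore expected to move this assay back upward, with a step of an at least 7.5-fold higher number from compound 2 to compound 4 (0.87 log units; beyond the scatter) beyond the scatter, to roughly the level of compound 1. The estimate for compound 4 in this assay is 12 ug/mL, with a range of 4 ug/mL to 40 ug/mL.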

Compound 4, solubility: 50 ug/mL
For compound 4 the middle estimate is 4.2-fold (0.62 log units) below the measured one; the measured number lies above the stated range.
By their numbers in this assay, from the lowest: compounds 1 and 3 (each within the scatter of the next); then compound 4. At a limit, below all of these: compound 2.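

In this assay, for the compounds shown here, ((piperidin-4-yl)oxy)methyl in place of piperidin-4-yl on a saturated chain carbon bound to an oxygen on an aromatic ring gives a 4.0-fold higher number from compound 1 to compound 4 (0.60 log units; beyond the scatter), and 2-((piperidin-4-yl)oxy)ethoxy in place of (4-aminopiperidin-1-yl)sulfonyl on an aromatic carbon gives a 4.0-fold higher number from compound 3 to compound 4 (0.60 log units; beyond the scatter), so the series now has changes that raise the reading beyond the scatter, where the earlier steps showed only a drop or no change. At the chain position, (piperidin-4-yl)oxy in place of (4-(methylsulfonyl)piperazin-1-yl)methyl gives an at least 31-fold higher number from compound 2 to compound 4 (1.49 log units; beyond the scatter), so the chain end decides much of the reading here, and a chain of this reach does not itself hold the reading down. Compound 2 stands at a limit of the assay and not at a number, so the size of that step is bounded only: the limit of < 1.6 ug/mL in this assay, at which 1 of the 4 values shown sits.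

Still open, from the compounds shown here alone, is whether the rise in compound 4 follows the oxygen inside the chain or the chain's length, which an all-carbon chain ending in the same piperidin-4-yl ring would separate. Also open, going by these compounds, is how far the free ring amine matters, which a methyl group on the piperidine nitrogen or a carboxylic acid at the chain end would test.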